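Nitrofuran chalcones: cytotoxicity step from compound 3 to compound 4

The source may hold more compounds than are shown below. What is called first, only, known or untested is meant among the compounds shown, and "the series" means these compounds.

The series shares the nitrofuranyl enone core; three members have numbers in a toxicity assay on Vero cells (Chlorocebus sabaeus) for cytotoxicity; on this read-out lower numbers stand for higher toxicity in this test and higher numbers for lower toxicity in this test. Compound 1 `Cc1ccc(C(=O)/C=C/c2ccc([N+](=O)[O-])o2)cc1` gives 439000 nM; compound 2 `O=C(/C=C/c1ccc([N+](=O)[O-])o1)c1ccc(Br)cc1` gives 354000 nM; compound 3 `O=C(/C=C/c1ccc([N+](=O)[O-])o1)c1ccc(OCc2ccc(F)cc2)cc1` gives 430000 nM. Compound 3 stands second highest of the three, and all three lie within the scatter of one another: the steps of a 1.2-fold lower number from compound 1 to compound 2 (0.09 log units; within the scatter), a 1.0-fold lower number from compound 1 to compound 3 (0.01 log units; within the scatter) and a 1.2-fold higher number from compound 2 to compound 3 (0.08 log units; within the scatter) are each within the scatter. Compound 4 `O=C(/C=C/c1ccc([N+](=O)[O-])o1)c1ccc(OCc2ccc(OC(F)(F)F)cc2)cc1` differs from compound 3 by trifluoromethoxy in place of fluoro on an aromatic carbon; the change sits on the outer ring, para to a large group.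

Among the measured compounds shown here, no measured step touches the outer ring; the three measured steps all alter the aromatic carbon of the core ring, and all of them left this assay unchanged beyond the scatter. By this indirect analogy the expected step of a 1.1-fold lower number from compound 3 to compound 4 (0.03 log units; within the scatter) is none beyond the scatter, in no particular direction. Compound 4 is therefore estimated at 400000 nM, with a range from 200000 nM to 800000 nM.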

Compound 4, half-maximal cytotoxic concentration: 335000 nM
Estimate against measurement, compound 4: 1.2-fold (0.08 log units) above, and the stated range covers the measured number.
By their numbers in this assay, from the lowest: compounds 4, 2, 3 and 1 (each within the scatter of the next).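

Among the compounds shown here, this is the first measured change on the outer ring: in this assay, trifluoromethoxy in place of fluoro gives a 1.3-fold lower number from compound 3 to compound 4 (0.11 log units; within the scatter). The earlier steps shown here tested only the aromatic carbon of the shared core, so this result extends the flat picture to an aromatic carbon para to a large group on the outer ring. None of the measured steps in the series now lies beyond the scatter at either site, and no data on hand bear on the reason for this.

Going by these compounds, whether an amine or a carboxylic acid in place of trifluoromethoxy on the outer ring would move this assay beyond the scatter remains open. The same question stands for a longer chain in place of the trifluoromethoxy group.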